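From 3-fluorophenyl to phenyl in compound 3

The source may report more compounds than this note shows. Statements on the series, on what has been measured and on what is new or still open speak of the compounds shown alone.

In a functional assay on MKN-45 cells (Homo sapiens) for inhibition, with a stated time of 72 h (on this read-out lower numbers stand for stronger inhibition and higher numbers for weaker inhibition), compound 2 (`COc1ccc(S(=O)(=O)N2CCc3cccc(-c4cccc(F)c4)c32)cc1`) gives 84.7 nM and compound 1 (`COc1ccc(S(=O)(=O)N2CCc3cccc(-c4ccc(F)c(F)c4)c32)cc1`) gives 55.5 nM so the two stand within the usual scatter of each other. Compound 3 (`COc1ccc(S(=O)(=O)N2CCc3cccc(-c4ccccc4)c32)cc1`) turns the 3-fluorophenyl of compound 2 into phenyl, hydrogen in place of fluoro on an aromatic carbon. For the measured compounds named here, the same kind of replacement has been measured once, as a 1.5-fold higher number from compound 1 to compound 2 (0.18 log units; within the scatter) and this is the only step that bears on it. The step expected is a 1.4-fold higher number from compound 2 to compound 3 (0.13 log units; within the scatter) in this assay and it would stay within the scatter. Compound 3 is estimated at 115 nM (55 nM to 240 nM).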

Compound 3, half-maximal inhibitory concentration: 117 nM
The estimate for compound 3 lay 1.0-fold (0.01 log units) below the measured number; the range from low to high includes it.
By their numbers in this assay, from the lowest: compounds 1, 2 and 3 (each within the scatter of the next, the first and the last beyond it).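

In this assay, the step from 3-fluorophenyl to phenyl is a 1.4-fold higher number from compound 2 to compound 3 (0.14 log units; within the scatter) and stays within the scatter on its own. Taken together, however, the replacement of both fluoro groups gives a 2.1-fold higher number from compound 1 to compound 3 (0.32 log units; beyond the scatter), the first step at this position to pass beyond the scatter, though it is modest. No available evidence accounts for either step. Going by these compounds, whether an amine or a carboxylic acid on this aromatic ring would move the number in either direction remains open.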